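Pyrazine in place of phenyl on the benzyloxy arm

The compounds below may be only part of what the source reports. "The series", "measured", "known", "first", "only" and "open" are said of these compounds alone.

Compound 1 `O=C(COCc1ccccc1)N1CCN(c2ccc(Cl)cc2)CC1` gives 350 nM in a functional assay on HEK293 cells for positive allosteric modulation of metabotropic glutamate receptor 5 (Homo sapiens), read by FLIPR and calcium flux; on this read-out higher numbers stand for an effect only at larger amounts of compound and lower numbers for an effect already at smaller amounts.
Compound 2 `O=C(COCc1ccccc1)N1CCN(c2ccc(Cl)cc2Cl)CC1` gives 1000 nM in this assay.
Compound 3 `O=C(COCc1ccccc1)N1CCN(c2ccc(F)cc2Cl)CC1` gives 270 nM in this assay.

Compound 2 holds the highest number of the three. The step of a 2.9-fold higher number from compound 1 to compound 2 (0.46 log units; beyond the scatter) and the step of a 3.7-fold lower number from compound 2 to compound 3 (0.57 log units; beyond the scatter) both lie beyond the scatter, whereas the step of a 1.3-fold lower number from compound 1 to compound 3 (0.11 log units; within the scatter) stays within it, so compound 1 and compound 3 cannot be ordered against each other.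

Compound 4 `O=C(COCc1cnccn1)N1CCN(c2ccc(Cl)cc2Cl)CC1` differs from compound 2 in one place: pyrazin-2-yl in place of phenyl on a saturated chain carbon bound to an oxygen on a saturated carbon. None of the three measured steps touches this part of the molecule; each of them changes the ring on the amine nitrogen of the shared core, at the other end of the structure. Within the data shown here, there is therefore no measured step that bears on the change, and no direction can be read from the data. In this assay compound 4 is expected to give about 1500 nM, within a wide range from 400 nM to 6000 nM. The expected step of a 1.5-fold higher number from compound 2 to compound 4 (0.18 log units; within the scatter) is accordingly set close to none beyond the scatter, with the width of the range carrying the uncertainty.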

Compound 4, half-maximal effective concentration: 5200 nM
Beside the measured number, compound 4's estimate is 3.5-fold (0.54 log units) below it; low and high end bracket the measured number.
By their numbers in this assay, from the lowest: compounds 3 and 1 (each within the scatter of the next); then compound 2; then compound 4.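

Among these compounds, the benzyloxy arm turns out to matter in this assay: all the earlier steps changed the ring on the amine nitrogen, and this is the first measured change at the other end of the molecule. Here a 5.2-fold higher number from compound 2 to compound 4 (0.72 log units; beyond the scatter) lies beyond the scatter, so compound 4 needs a larger amount to act, even though the ring keeps its six heavy atoms and the swap puts two ring nitrogens and two hydrogen-bond acceptors in place of carbon. Nothing measured here explains why this swap raises the number.

As far as these compounds go, whether pyrazin-2-yl would move the number in the same direction with the 4-chlorophenyl group of compound 1 remains open. So does the question of where a pyridin-2-yl ring, with a single ring nitrogen, or a cyclohexyl ring would fall on this arm.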